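Nitro for Methoxy on Thiophene Sulfonamide Ureas and Thioureas

The compounds below may be only part of what the source reports. "The series", "measured", "known", "first", "only" and "open" are said of these compounds alone.

Compound 1 `COc1cccc(NC(=O)NCCNS(=O)(=O)c2ccc(-c3ccccc3OCc3ccccc3)s2)c1`: > 20000 nM
Compound 2 `COc1ccc(NC(=S)NCCNS(=O)(=O)c2sccc2-c2ccc(C)cc2Oc2ccc(O)c(O)c2)cc1`: > 20000 nM
Compound 3 `O=C(NCCNS(=O)(=O)c1ccc(-c2ccccc2OCc2ccccc2)s1)Nc1cccc([N+](=O)[O-])c1`: 13300 nM

Of the compounds shown here, three have been measured in an ADME assay on HEK-293T cells (Homo sapiens) for cytotoxicity, read by CCK-8 assay, with a stated time of 48 h; on this read-out lower numbers stand for stronger inhibition and higher numbers for weaker inhibition. Compound 1 gives only a limit of the assay, > 20000 nM. Compound 2 likewise gives only a limit, > 20000 nM. Compound 3 gives a number, 13300 nM. The difference between compound 1 and compound 3 is nitro in place of methoxy on an aromatic carbon, and this step is an at least 1.5-fold lower number from compound 1 to compound 3 (0.17 log units; that floor lies within the scatter). The difference between the cores of compound 1 and compound 2 is not broken down here.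

Compound 4 `Cc1ccc(-c2ccsc2S(=O)(=O)NCCNC(=S)Nc2ccc([N+](=O)[O-])cc2)c(Oc2ccc(O)c(O)c2)c1` has not yet been measured. It differs from compound 2 by nitro in place of methoxy on an aromatic carbon. The two places are not the same: in compound 3 the nitro sits meta to a large group, in compound 4 para to a large group, so this is the same kind of change, not the same change. The expected step is an at least 1.2-fold lower number from compound 2 to compound 4 (0.09 log units; that floor lies within the scatter), resting on the measured step in compound 3, an at least 1.5-fold lower number from compound 1 to compound 3 (0.17 log units; that floor lies within the scatter), and on (the limit of > 20000 nM in this assay, at which 2 of the 3 values shown sit). Compound 4 is therefore expected to give about 16000 nM, in a range of 8000 nM to 40000 nM.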

Compound 4, half-maximal inhibitory concentration: 8200 nM
Beside the measured number, compound 4's estimate is 2.0-fold (0.29 log units) above it; the measured number falls inside the stated range.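

In this assay, nitro in place of methoxy on the core of compound 2 gives an at least 2.4-fold lower number from compound 2 to compound 4 (0.38 log units; beyond the scatter), a step that is clearly larger than the usual scatter. This shows that the change can lower the number on this second core, but not that a step of the same size carries over from the core of compound 1, where the floor of the step stays within the scatter: the same change on two cores in this assay, an at least 1.5-fold lower number (0.17 log units; that floor lies within the scatter) from compound 1 to compound 3 and an at least 2.4-fold lower number (0.38 log units; beyond the scatter) from compound 2 to compound 4; the limit leaves it open whether they differ Neither step has a known full size, as each one starts from a limit of the assay rather than a number: the limit of > 20000 nM in this assay, at which 2 of the 4 values shown sit.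

The compounds shown leave open whether nitro would give the same step at the same ring position on a single core, since the urea and thiourea pairs also differ in where the group sits. They also leave open what an amine or a carboxylic acid in place of the methoxy would do to the number.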